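The compounds below may be only part of what the source reports. "The series", "measured", "known", "first", "only" and "open" are said of these compounds alone.

Compound 1 `CCCCCC/N=C(\C)c1c(O)c2ccccc2oc1=O` is the reference point of the series. In an assay on isolated protein for inhibition of myosin-2 (Bos taurus), read by spectrophotometry, with a stated time of 24 min (a higher number here means a weaker inhibitor, a lower number a stronger inhibitor), compound 1 gives 2900 nM, the lowest of the two numbers shown. Compound 2 `C/C(=N\Nc1ccccc1)c1c(O)c2ccccc2oc1=O` gives 27000 nM in this assay, the step being a 9.3-fold higher number from compound 1 to compound 2 (0.97 log units; beyond the scatter). Compound 3 `C/C(=N\C(C)C)c1c(O)c2ccccc2oc1=O` reaches only a limit in this assay, >= 100000 nM; this is the limit of >= 100000 nM in this assay, at which 1 of the 3 values shown sits. The steps of an at least 34-fold higher number from compound 1 to compound 3 (1.53 log units; beyond the scatter) and an at least 3.7-fold higher number from compound 2 to compound 3 (0.56 log units; beyond the scatter) show that both departures from hexyl cost potency. Compound 4 `C/C(=N\Cc1cccc(C)c1)c1c(O)c2ccccc2oc1=O` is not yet measured; its change from compound 1 is 3-methylphenyl in place of pentyl on a saturated chain carbon bound to a double-bonded nitrogen. Of the measured steps only a 9.3-fold higher number from compound 1 to compound 2 (0.97 log units; beyond the scatter) brings in a ring, and it is the smaller loss from compound 1. For compound 4 a modest weakening is therefore expected, a 2.4-fold higher number from compound 1 to compound 4 (0.38 log units; beyond the scatter). Compound 4 is estimated at 7000 nM in this assay, ranging from 2500 nM to 25000 nM.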

Compound 4, half-maximal inhibitory concentration: 4900 nM
Beside the measured number, compound 4's estimate is 1.4-fold (0.15 log units) above it; the measured number falls inside the stated range.
By their numbers in this assay, from the lowest: compounds 1 and 4 (each within the scatter of the next); then compound 2. At a limit, above all of these: compound 3.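

In this assay the change gives a 1.7-fold higher number from compound 1 to compound 4 (0.23 log units; within the scatter), so at this position on a saturated chain carbon bound to a double-bonded nitrogen, a six-membered aromatic ring can stand in place of pentyl without a change beyond the scatter. Among the compounds shown here, every earlier departure from compound 1 cost potency, whereas compound 4 is the first to hold its level. Nothing in the data shown accounts for this result.

Still open, from the compounds shown here alone, is whether the methyl on the ring contributes, as plain phenyl would show. Also open, going by these compounds, is how a chain longer than hexyl, or a ring bearing an amine or a carboxylic acid, would fare here.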